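Swapping bromo for methyl in compound 1

This account rests on a few compounds, and the source may have more. Where it says the series, first, only, none or still open, it means among the compounds named here.

In a functional assay on A549 cells (Homo sapiens) for antiproliferative activity, read by CCK-8 assay, with a stated time of 72 h (on this read-out higher numbers stand for weaker inhibition and lower numbers for stronger inhibition), compound 1 (`Nc1ccccc1NC(=O)c1ccc(COc2ccc(Br)cc2)cc1`) gives 24400 nM as its reading. In this assay compound 2 (`O=C(NO)c1ccc(COc2ccccc2)cc1`) gives 28000 nM as its reading, and these two numbers lie within the usual scatter of each other, so neither can be ranked over the other. A third relative, compound 3 (`Nc1ccccc1NC(=O)c1ccc(CN2CCc3cc(Br)ccc32)cc1`), is recorded as "not determined" (no result reported) with no reported result, which leaves just two numbers to work from.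

Compound 4 (`Cc1ccc(OCc2ccc(C(=O)Nc3ccccc3N)cc2)cc1`) has not been measured yet. It differs from compound 1 in one place (methyl in place of bromo on an aromatic carbon): methyl in place of bromo on an aromatic carbon, para to a large group, so that 4-bromophenoxy becomes 4-methylphenoxy. Within the data shown here, no measured pair shows a change of this kind, so the data offer no direct guide to its size or direction.

In this assay I therefore expect no shift beyond the scatter, and the best starting point is compound 1 at 24400 nM as its own reading. The expected step is a 1.1-fold higher number from compound 1 to compound 4 (0.06 log units; within the scatter) and it is only an estimate. For compound 4 the estimated value is 28000 nM within an expected range from 13000 nM to 60000 nM as a deliberately wide span.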

Compound 4, half-maximal inhibitory concentration: 5430 nM
The estimate for compound 4 lay 5.2-fold (0.71 log units) above the measured number, outside the stated range (below it).
By their numbers in this assay, from the lowest: compound 4; then compounds 1 and 2 (each within the scatter of the next).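

In this assay the 4-bromophenoxy end of compound 1 proves sensitive to change: going to 4-methylphenoxy gives a 4.5-fold lower number from compound 1 to compound 4 (0.65 log units; beyond the scatter) and this modest step lies beyond the usual scatter. Among these compounds, the earlier numbers could not be ranked against each other and formed no one-place pair, so they gave no sign that this position could move the reading at all; now a swap of one heavy atom for one heavy atom, on an aromatic carbon para to a large group, is seen to do so. Nothing measured here bears on the reason for the step.

A single pair cannot tell whether the lower number comes from gaining methyl or from losing bromo, and a plain hydrogen, a chloro or a methoxy group at this place would help separate those two readings. As far as these compounds go, it also remains open whether a longer chain such as ethyl or propyl would take the number lower still or bring it back up.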